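A few compounds are considered here, and "the series" means these few. Any claim that something is new, unique, unknown or untested is made for them only; others in the source may bear on it.

Two measured compounds anchor the series. Compound 1 `N=C(N)c1ccc(-c2ccc(-c3cc(Cl)cc(Cl)c3)s2)s1` in a functional assay on DU-145 cells (Homo sapiens) for inhibition, read by sulforhodamine B assay, with a stated time of 48 h (a higher number here means a weaker inhibitor of growth, a lower number a stronger inhibitor of growth), gives 1820 nM. Compound 2 `COc1ccc(-c2ccc(-c3ccc(C(=N)N)o3)o2)cc1` gives 1910 nM in this assay, the higher of the two numbers, though the gap to compound 1 lies within the scatter, so the two read as alike. Compound 3 `N=C(N)c1ccc(-c2ccc(-c3ccc(Cl)cc3)o2)o1` is not yet measured. It differs from compound 2 by chloro in place of methoxy on an aromatic carbon. Among the measured compounds shown here, no measured pair shows this exchange here. The step is expected to be small, a 1.3-fold lower number from compound 2 to compound 3 (0.10 log units; within the scatter), with no clear direction beyond the scatter. Compound 3 is expected to give about 1500 nM, within 600 nM to 4000 nM, in this assay.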

Compound 3, concentration for 50% growth inhibition: 1750 nM
The estimate for compound 3 lay 1.2-fold (0.07 log units) below the measured number; the measured number falls inside the stated range.
By their numbers in this assay, from the lowest: compounds 3, 1 and 2 (each within the scatter of the next).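

Among the compounds shown here, the first measured exchange at this position, chloro in place of methoxy on an aromatic carbon para to a large group, gives a 1.1-fold lower number from compound 2 to compound 3 (0.04 log units; within the scatter) in this assay. Within this furan-free-of-claims pair, the position therefore accepts either group with no change that can be read beyond the scatter. No evidence bears on this result.

As far as these compounds go, whether an amine, a carboxylic acid or a longer alkoxy chain at this position would give a step beyond the scatter remains open.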